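The source may hold more compounds than are shown below. What is called first, only, known or untested is meant among the compounds shown, and "the series" means these compounds.

Compound 1 `COc1ccc(-c2cn3ccnc3c(-c3ccc4ncn(C5CCCCC5)c4c3)n2)cc1`, giving 62.2% in a functional assay on NCI-H23 cells (Homo sapiens) for inhibition, read by sulforhodamine B assay, with a stated time of 48 h, tested at 10 uM; on this read-out higher numbers stand for more inhibition at the one concentration tested (going by the name of the read-out) and lower numbers for less inhibition.
Compound 2 `Clc1ccc(-c2cn3ccnc3c(-c3ccc4ncn(C5CCCCC5)c4c3)n2)cc1`, giving 4.11% in this assay.

In this assay compound 2 stands lowest of the two numbers shown; its nearest neighbour is compound 1, and the step of a number 58.1 percentage points lower from compound 1 to compound 2 (beyond the scatter) sets the two well apart. Compound 3 `Brc1ccc(-c2cn3ccnc3c(-c3ccc4ncn(C5CCCCC5)c4c3)n2)cc1` is not yet measured. It differs from compound 2 by bromo in place of chloro on an aromatic carbon. Among the measured compounds shown here, the only measured step, that from compound 1 to compound 2, swaps methoxy for chloro; it does not involve bromo, so no measured step bears directly on the change from chloro to bromo. Since chloro and bromo are exchanged at the same aromatic carbon, the account expects compound 3 to stay close to compound 2, with a step of a number 5.9 percentage points higher from compound 2 to compound 3 (within the scatter) that need not exceed the scatter. The estimate for compound 3 in this assay is therefore 10%, in a range from 0% to 35%.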

Compound 3, a percentage reported as inhibition, at one concentration (the size of the read-out at that concentration, not a potency): 8.38%
Compound 3: middle estimate off by 1.6 percentage points, on the high side; measured number inside the range.
By their numbers in this assay, from the lowest: compounds 2 and 3 (each within the scatter of the next); then compound 1.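

In this assay, bromo and chloro on this aromatic carbon, para to a large group, cannot be told apart: the exchange gives a number 4.3 percentage points higher from compound 2 to compound 3 (within the scatter), so the choice between these two halogens makes no readable difference here. Bromo in place of methoxy gives a number 53.8 percentage points lower from compound 1 to compound 3 (beyond the scatter), which means the large gap to compound 1 now holds for two different halogens rather than for chloro alone. Nothing available explains why compound 1 stands apart from the two halogen compounds.

From the compounds shown here alone, it remains open whether an amine, a hydroxyl or an ethoxy group at this place would fall with compound 1 or with compounds 2 and 3. Fluoro is also open, as is whether the gap persists when the cyclohexyl group is replaced by a shorter chain.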